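The compounds below may be only part of what the source reports. "The series", "measured", "known", "first", "only" and "open" are said of these compounds alone.

In a physicochemical assay for solubility, at pH 6.8 (on this read-out higher numbers stand for higher solubility and lower numbers for lower solubility), three compounds have been read so far. Compound 1 `Nc1ncc(-c2ccc(CN3CCC(N4CCCC4)CC3)cc2)nc1C(=O)N[C@H]1CC[C@H](O)CC1` gives > 1000000 nM; > 1000000 nM (2 entries), which is a limit of the assay and not a number. Compound 2 `CCNC(=O)c1nc(-c2ccc(CN(C)C)cc2)cnc1N` gives > 1000000 nM, again a limit. Within the data shown here, compound 3 `CN(C)Cc1ccc(-c2cnc(N)c(C(=O)NC3CCC(O)CC3)n2)cc1` gives 850000 nM, the only actual number among the three.

Compound 4 `CC(O)CNC(=O)c1nc(-c2ccc(CN(C)C)cc2)cnc1N` has not yet been measured. It departs from compound 3 with 2-hydroxypropyl in place of 4-hydroxycyclohexyl on an amide-type nitrogen.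

Among the measured compounds shown here, one measured step bears on this place, the exchange of ethyl for 4-hydroxycyclohexyl on an amide-type nitrogen. It amounts to an at least 1.1-fold lower number from compound 2 to compound 3 (0.07 log units; that floor lies within the scatter), and it rests on a limit, so it gives only a floor on the size of the step. Since that step stays within the scatter, and compound 4 carries a chain without a ring, as compound 2 does with its ethyl, no change beyond the scatter is expected in this assay. The expected step is a 1.1-fold higher number from compound 3 to compound 4 (0.05 log units; within the scatter), which is no real shift in either direction.

For compound 4 the estimated value is 950000 nM, with an expected range from 550000 nM to 1500000 nM.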

Compound 4, solubility: > 1000000 nM
Compound 4: a limit, no number; the forecaster's own chance of this, stated with the estimate: 55%; middle value at least 1.0-fold (0.02 log units) away from the limit.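

In this assay, among these compounds, 2-hydroxypropyl in place of 4-hydroxycyclohexyl on an amide-type nitrogen gives an at least 1.1-fold higher number from compound 3 to compound 4 (0.07 log units; that floor lies within the scatter), so this is the first reading of an open chain bearing a hydroxyl at this position, and its floor shows no step beyond the scatter from the ring-bearing compound 3. Compound 4 gives > 1000000 nM, which is a limit of the assay and not a number, so the true size of the step may be larger than its floor. The step from compound 2 to compound 4 cannot be read, so the data cannot separate 2-hydroxypropyl from ethyl, and the readings at this position stop at a shared ceiling: the limit of > 1000000 nM in this assay, at which 2 of the 4 values shown sit.

From the compounds shown here alone, what stays open is how far the readings of compound 2 and compound 4 extend past that limit, and whether the ring in compound 3 matters at all. Going by these compounds, it is also open whether a different group on this nitrogen, such as a chain ending in a primary amine or a carboxylic acid, would bring a step beyond the scatter in this assay.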